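Phenyl in Place of Cyano: A Cytotoxicity Step

The source may report more compounds than this note shows. Statements on the series, on what has been measured and on what is new or still open speak of the compounds shown alone.

Of the compounds shown here, three sharing one core have been read in an ADME assay on MDBK cells (Bos taurus) for cytotoxicity; on this read-out lower numbers stand for higher toxicity in this test and higher numbers for lower toxicity in this test. Compound 1 (`COc1ccc(Cn2ccc3nc(-c4ccccc4)nc-3c2)cc1`) gives > 100000 nM, which is a limit. Compound 2 (`Brc1ccc(Cn2ccc3nc(-c4ccccc4)nc-3c2)cc1`) gives a true number, 83000 nM. Compound 3 (`N#Cc1ccc(Cn2ccc3nc(-c4ccccc4)nc-3c2)cc1`) gives > 100000 nM, which is again a limit. Where compound 3 stands is therefore marked only by the limit of > 100000 nM in this assay, at which 2 of the 3 values shown sit.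

Compound 4 (`c1ccc(-c2ccc(Cn3ccc4nc(-c5ccccc5)nc-4c3)cc2)cc1`) carries phenyl in place of the cyano of compound 3, on an aromatic carbon para to a large group: phenyl in place of cyano on an aromatic carbon.

The measured changes all fall at this same place. Bromo in place of methoxy gave an at least 1.2-fold lower number from compound 1 to compound 2 (0.08 log units; that floor lies within the scatter). Cyano in place of bromo gave an at least 1.2-fold higher number from compound 2 to compound 3 (0.08 log units; that floor lies within the scatter). Cyano in place of methoxy gave a step that the two limits leave unreadable from compound 1 to compound 3. None of these steps involves phenyl, so they fix no size for the new group. Within the data shown here, with compound 2 at 83000 nM as the only number in the set, at most a small fall is expected in this assay, and no step clearly beyond the scatter can be argued.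

The expected change is an at least 1.2-fold lower number from compound 3 to compound 4 (0.09 log units; that floor lies within the scatter). Compound 4 is estimated at 80000 nM, with an expected range of 30000 nM to 150000 nM.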

Compound 4, half-maximal cytotoxic concentration: 18000 nM
The estimate for compound 4 lay 4.4-fold (0.65 log units) above the measured number, and the stated range ends above it.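

In this assay, among these compounds, this position proves able to shift the read-out clearly, which none of the earlier groups showed: phenyl, the only group here that brings a six-membered aromatic ring of its own to this place, gives a 4.6-fold lower number from compound 2 to compound 4 (0.66 log units; beyond the scatter). Among the compounds shown here, that step from bromo is the only one of the new steps with a true size, and it is the first step at this position with a readable size beyond the scatter. The other two, an at least 5.5-fold lower number from compound 3 to compound 4 (0.74 log units; beyond the scatter) and an at least 5.5-fold lower number from compound 1 to compound 4 (0.74 log units; beyond the scatter), also lie beyond the scatter, but they give only floors for the change, because their starting values are limits: the limit of > 100000 nM in this assay, at which 2 of the 4 values shown sit.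

The compounds shown leave open whether the fall follows the aromatic ring itself or simply the larger group, as a saturated cyclohexyl ring or a longer alkyl chain at this place would help to tell. They also leave open whether a pyridyl ring, or a phenyl ring carrying an amine or a carboxylic acid, would keep the lower number seen with compound 4.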